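From thiophen-2-yl to thiophen-3-yl

A few compounds are considered here, and "the series" means these few. Any claim that something is new, unique, unknown or untested is made for them only; others in the source may bear on it.

Measured so far in a functional assay on MDA-MB-231 cells (Homo sapiens) for cytotoxicity, read by ELISA, with a stated time of 2 days; a higher number here means a weaker inhibitor, a lower number a stronger inhibitor
compound 1 `Oc1cccc(-c2cc(-c3ccccc3)cc(-c3ccsc3)n2)c1` gives 12100 nM
compound 2 `Oc1ccc(-c2cc(-c3ccccc3)cc(-c3ccccc3)n2)cc1` gives 1300 nM
compound 3 `Oc1ccc(-c2cc(-c3ccccc3)cc(-c3cccs3)n2)cc1` gives 2400 nM

Compound 3 lies within the scatter of compound 2 and well under compound 1. Compound 4 `Oc1ccc(-c2cc(-c3ccccc3)cc(-c3ccsc3)n2)cc1` replaces the thiophen-2-yl of compound 3 with thiophen-3-yl thiophen-3-yl in place of thiophen-2-yl on an aromatic carbon on an aromatic carbon next to the ring nitrogen. Among the measured compounds shown here, the only measured step at this place is a 1.8-fold higher number from compound 2 to compound 3 (0.27 log units; within the scatter) for thiophen-2-yl in place of phenyl, and it stays within the scatter. Compound 1 also carries thiophen-3-yl but lacks the 4-hydroxyphenyl group, so it is only a loose guide. No step beyond the scatter is expected in this assay here. The expected step is a 1.1-fold lower number from compound 3 to compound 4 (0.04 log units; within the scatter) and no more than that. For compound 4 the estimate is 2200 nM within an expected range of 900 nM to 5500 nM.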

Compound 4, half-maximal inhibitory concentration: 5700 nM
For compound 4 the middle estimate is 2.6-fold (0.41 log units) below the measured one; the whole stated range lies below it.
By their numbers in this assay, from the lowest: compounds 2 and 3 (each within the scatter of the next); then compound 4; then compound 1.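

In this assay the two thiophene groups are not interchangeable at this position: thiophen-3-yl in place of thiophen-2-yl (a 2.4-fold higher number from compound 3 to compound 4 (0.38 log units; beyond the scatter)) is a step beyond the scatter, even though the two groups have the same atoms. Thiophen-3-yl in place of phenyl (a 4.4-fold higher number from compound 2 to compound 4 (0.64 log units; beyond the scatter)) also goes beyond the scatter, unlike thiophen-2-yl in place of phenyl, and 4-hydroxyphenyl in place of 3-hydroxyphenyl (a 2.1-fold lower number from compound 1 to compound 4 (0.33 log units; beyond the scatter)) shows that a change elsewhere on the core counts too. Nothing measured here accounts for these steps.

Going by these compounds, how an amine or a carboxylic acid at this position would compare remains open. So does whether the gap between the two thiophene groups would hold alongside 3-hydroxyphenyl.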